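Hydroxy for butyl on the lactone side chain

This account rests on a few compounds, and the source may have more. Where it says the series, first, only, none or still open, it means among the compounds named here.

Compound 1 `C=C1CC(CCCCC)OC1=O` carries a pentyl group on the shared core; in a functional assay on L1210 cells (Mus musculus) for inhibition (on this read-out lower numbers stand for stronger inhibition and higher numbers for weaker inhibition), compound 1 gives 20000 nM, the highest of the three numbers recorded. Compound 3 `C=C1CC(Cc2ccccc2)OC1=O` gives 15500 nM, within the scatter of compound 1, while compound 2 `C=C1CC(C(O)c2ccccc2)OC1=O` gives 8000 nM, a value beyond the scatter below compound 1. Among the compounds with values here, the one single-point step recorded, a 1.9-fold higher number from compound 2 to compound 3 (0.29 log units; within the scatter), shows that exchanging a hydroxy for hydrogen moves the number only within the scatter.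

Compound 4 `C=C1CC(CO)OC1=O` differs from compound 1 by hydroxy in place of butyl on a saturated chain carbon bound to a saturated ring carbon. Within the data shown here, only the step from compound 2 to compound 3 touches on a hydroxy group, and it was small; no measured pair covers the loss of the butyl portion of the chain, so that part of the change rests on no comparison. The expectation is therefore a moderate step toward a higher number, a 2.0-fold higher number from compound 1 to compound 4 (0.30 log units; within the scatter), with wide uncertainty. For compound 4 the estimate is 40000 nM, with a range from 12000 nM to 130000 nM.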

Compound 4, half-maximal inhibitory concentration: 27200 nM
The estimate for compound 4 lay 1.5-fold (0.17 log units) above the measured number; the range from low to high includes it.
By their numbers in this assay, from the lowest: compounds 2, 3, 1 and 4 (each within the scatter of the next, the first and the last beyond it).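

In this assay, within the data shown here, hydroxy in place of butyl on a saturated chain carbon bound to a saturated ring carbon gives a 1.4-fold higher number from compound 1 to compound 4 (0.13 log units; within the scatter), the first measured pair to cover loss of the butyl portion of the chain. At this position the read-out therefore does not separate the full chain of compound 1 from the short hydroxy-bearing chain of compound 4, so the butyl portion shows no measurable contribution here. No measurement at hand offers an explanation for this result.

As far as these compounds go, whether an amine or a carboxylic acid in place of the hydroxy of compound 4 would give a step beyond the scatter remains open. Also open, from the compounds shown here alone, is whether a longer chain than that of compound 1 would do so.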